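From 2-bromophenyl to 2,4-dimethylphenyl on a shared core

This account rests on a few compounds, and the source may have more. Where it says the series, first, only, none or still open, it means among the compounds named here.

In a functional assay (on this read-out higher numbers stand for weaker inhibition and lower numbers for stronger inhibition), three compounds sharing one core have been measured: compound 1 `CC(C)=CCOc1ccc2c(c1)OC(c1ccccc1Cl)CC2=O` gives 8020 nM, compound 2 `CC(C)=CCOc1ccc2c(c1)OC(c1ccc(Cl)cc1Cl)CC2=O` gives 5260 nM and compound 3 `CC(C)=CCOc1ccc2c(c1)OC(c1ccccc1Br)CC2=O` gives 3180 nM. Two steps show where the last of these stands: a 1.7-fold lower number from compound 2 to compound 3 (0.22 log units; within the scatter), and a 2.5-fold lower number from compound 1 to compound 3 (0.40 log units; beyond the scatter).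

The next compound, compound 4 `CC(C)=CCOc1ccc2c(c1)OC(c1ccc(C)cc1C)CC2=O`, carries 2,4-dimethylphenyl in place of 2-bromophenyl on a saturated ring carbon. For the measured compounds named here, no measured compound has a methyl group on this aromatic ring, so the evidence is indirect. The closest guides are the bromo-for-chloro step above, which was modest, and a 1.5-fold lower number from compound 1 to compound 2 (0.18 log units; within the scatter), where a chloro replaces a hydrogen on an aromatic carbon. Neither step is large, so only a small change is expected in this assay, with no clear direction from the data. The expected change is a 1.4-fold higher number from compound 3 to compound 4 (0.15 log units; within the scatter), a slight shift toward the higher values of the series. For compound 4 the estimated value is 4500 nM, with an expected range from 1800 nM to 11000 nM.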

Compound 4, half-maximal inhibitory concentration: 8260 nM
Compound 4: middle estimate off by 1.8-fold (0.26 log units), on the low side; low and high end bracket the measured number.
By their numbers in this assay, from the lowest: compounds 3, 2, 1 and 4 (each within the scatter of the next, the first and the last beyond it).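

In this assay, for the compounds shown here, 2,4-dimethylphenyl in place of 2-bromophenyl on this saturated ring carbon next to the ring oxygen gives a 2.6-fold higher number from compound 3 to compound 4 (0.41 log units; beyond the scatter) as a modest step beyond the scatter, the first change at this position to a ring without halogen. The comparisons with the chlorinated rings read differently: a 1.6-fold higher number from compound 2 to compound 4 (0.20 log units; within the scatter) and a 1.0-fold higher number from compound 1 to compound 4 (0.01 log units; within the scatter) both lie within the scatter, so among compounds 1, 2 and 4 the methyl groups cannot be told apart from the chloro groups on this read-out. No available evidence accounts for these differences.

Compound 4 changes two places on the ring at once, so the contribution of each methyl group remains unresolved. Going by these compounds, it also remains open how a ring carrying a single methyl group, a methoxy group or an amine would stand.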